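A Carbamate Chain in Place of the Benzyl Group

A few compounds are considered here, and "the series" means these few. Any claim that something is new, unique, unknown or untested is made for them only; others in the source may bear on it.

Compound 2 `CCCSc1nc(Cl)c2c(n1)N(Cc1ccccc1)C(C(=O)N1CCN(C)CC1)N2` carries a phenyl on a saturated chain carbon bound to a nitrogen on an aromatic ring in a ring. Among the compounds with values here, in a functional assay on PC-3 cells (Homo sapiens) for antiproliferative activity, read by MTT assay, with a stated time of 72 h (a lower number here means a stronger inhibitor, a higher number a weaker inhibitor), compound 2 gives 29800 nM, the highest of the two numbers measured so far; its nearest neighbour, compound 1 `CCCSc1nc(Cl)c2c(n1)N(Cc1cccs1)C(C(=O)N1CCN(C)CC1)N2`, gives 5020 nM. Within the data shown here, the only measured step at this position, a 5.9-fold higher number from compound 1 to compound 2 (0.77 log units; beyond the scatter), shows that the group placed there can move the number well beyond the scatter. Compound 3 `CCCSc1nc(Cl)c2c(n1)N(CCNC(=O)OC(C)(C)C)C(C(=O)N1CCN(C)CC1)N2` differs from compound 2 by ((tert-butoxycarbonyl)amino)methyl in place of phenyl on a saturated chain carbon bound to a nitrogen on an aromatic ring in a ring. Among the measured compounds shown here, no measured step covers a change of this kind, so its direction cannot be read from the data. The estimated step of a 1.5-fold lower number from compound 2 to compound 3 (0.17 log units; within the scatter) therefore stays small, with a wide range to allow for a shift in either direction. For compound 3 the expected value is 20000 nM, estimated to lie within 5000 nM to 70000 nM.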

Compound 3, half-maximal inhibitory concentration: > 64000 nM
Compound 3: only a limit was reported; the forecaster's own chance of this, stated with the estimate: 15%; middle value at least 3.2-fold (0.50 log units) away from the limit.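

The value of compound 3 in this assay, > 64000 nM, is a limit and not a number: the limit of > 64000 nM in this assay, at which 1 of the 3 values shown sits. Even so, the direction that could not be read before can now be read: ((tert-butoxycarbonyl)amino)methyl in place of phenyl gives an at least 2.1-fold higher number from compound 2 to compound 3 (0.33 log units; beyond the scatter), and the same group in place of thiophen-2-yl gives an at least 12-fold higher number from compound 1 to compound 3 (1.10 log units; beyond the scatter). The earlier step compared two aromatic rings only, whereas these steps show that this chain without a ring, on a saturated chain carbon bound to a nitrogen on an aromatic ring in a ring, gives a higher number than either ring.

The compounds shown leave open whether the tert-butoxycarbonyl part or the loss of the ring carries this step. They also leave open how a free amine on the same chain, or a plain longer alkyl chain, would read in this assay.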